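A few compounds are considered here, and "the series" means these few. Any claim that something is new, unique, unknown or untested is made for them only; others in the source may bear on it.

Measured so far in a functional assay on SK-BR-3 cells (Homo sapiens) for antiproliferative activity, read by MTT assay, with a stated time of 72 h; on this read-out lower numbers stand for stronger inhibition and higher numbers for weaker inhibition:
compound 1 `CCN1CCN(c2cc(C)c3cc(NC(=O)c4ccc(C)cc4)ccc3n2)CC1`: 11400 nM
compound 2 `CCc1ccccc1C(=O)Nc1ccc2nc(N3CCN(CC)CC3)cc(C)c2c1`: 23900 nM
compound 3 `Cc1cc(N(C)C)nc2ccc(NC(=O)c3ccc(Cl)c(Cl)c3)cc12`: > 50000 nM, which is a limit of this assay and not a number the limit of > 50000 nM in this assay, at which 1 of the 3 values shown sits.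

Compound 2 gives the highest of the two numbers in this assay. Within the data shown here, the only measured step is a 2.1-fold higher number from compound 1 to compound 2 (0.32 log units; beyond the scatter); it sets compound 1 apart from compound 2 beyond the scatter, with compound 1 the lower of the two. Compound 3 is known only by its limit in this assay.

Compound 4 `CCc1ccc(C(=O)Nc2ccc3nc(N4CCN(CC)CC4)cc(C)c3c2)cc1` has not yet been measured in this assay. It differs from compound 2 in one place: 4-ethylphenyl in place of 2-ethylphenyl on a carbonyl carbon. The step from compound 1 to compound 2 is the only one that bears on it, since compound 1 carries 4-methylphenyl on the same carbonyl carbon, and the 4-ethylphenyl of compound 4 shares that pattern while adding one carbon to the chain. That step, a 2.1-fold higher number from compound 1 to compound 2 (0.32 log units; beyond the scatter), was modest but beyond the scatter, so compound 4 is expected to move back towards compound 1, with a step of about a 2.0-fold lower number from compound 2 to compound 4 (0.30 log units; within the scatter) in this assay. The estimate for compound 4 is therefore 12000 nM, expected to fall between 5000 nM and 30000 nM.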

Compound 4, half-maximal inhibitory concentration: 9850 nM
For compound 4 the middle estimate is 1.2-fold (0.09 log units) above the measured one; the range from low to high includes it.
By their numbers in this assay, from the lowest: compounds 4 and 1 (each within the scatter of the next); then compound 2. At a limit, above all of these: compound 3.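

In this assay, the change from 2-ethylphenyl to 4-ethylphenyl on a carbonyl carbon keeps the same atoms joined differently and gives a 2.4-fold lower number from compound 2 to compound 4 (0.38 log units; beyond the scatter), so where the ethyl sits on the phenyl ring separates these two compounds with no change in atom count. The change from 4-methylphenyl to 4-ethylphenyl gives a 1.2-fold lower number from compound 1 to compound 4 (0.06 log units; within the scatter), so the extra methyl on the chain does not separate these two compounds. The earlier step from compound 1 to compound 2 changed the chain and its place together, and these two steps now tie that difference to the place of the ethyl rather than to the added carbon, though nothing at hand bears on the cause of this.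

Compound 3 is known only by a limit of this assay, > 50000 nM, and it differs from the other compounds in more than one place, so its steps cannot be read. Still open, on these data alone, is whether 4-propylphenyl, a longer chain, or 4-aminophenyl, which carries an amine, on the same carbonyl carbon would give a number that stands apart from those of compound 1 and compound 4.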